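This account rests on a few compounds, and the source may have more. Where it says the series, first, only, none or still open, it means among the compounds named here.

Compound 1 `CC(C)(C)[C@H]1CC[C@H](N(C(=O)Nc2ccc(OC(F)(F)F)cc2)C2CCOc3cc(C(=O)Nc4nn[nH]n4)ccc32)CC1` was tested in a functional assay on CHO cells for antagonist activity at Glucagon receptor (Homo sapiens), read by cAMP accumulation (on this read-out higher numbers stand for weaker inhibition and lower numbers for stronger inhibition), where the repeated entries for compound 1 give 1450 nM; 39 nM (2 entries). Compound 2 `CC(C)(C)[C@H]1CC[C@H](N(C(=O)c2ccc(OC(F)(F)F)cc2)C2CCc3cc(C(=O)NCCC(=O)O)ccc32)CC1` gives 2780 nM in this assay, the only number shown for it, and a further entry for compound 2 carries no single number. Compound 3 `CC(C)(C)[C@H]1CC[C@H](N(C(=O)Nc2cc(Cl)cc(Cl)c2)C2CCc3cc(C(=O)NCCC(=O)O)ccc32)CC1` has not yet been measured in this assay. Compound 3 differs from compound 2 in one place, ((3,5-dichlorophenyl)amino in place of 4-(trifluoromethoxy)phenyl on a carbonyl carbon), so that the carbonyl carbon now carries an amide-type nitrogen on both sides. For the measured compounds named here, no measured pair shows this exact change. The wide spread between the entries of compound 1 the several entries of compound 1 in this assay, 1450 nM; 39 nM (2 entries) shows how far repeats in this assay can lie apart. Compound 3 is expected to show stronger inhibition than compound 2, a step of a 9.3-fold lower number from compound 2 to compound 3 (0.97 log units; beyond the scatter). The estimate for compound 3 in this assay is 300 nM, within a range from 50 nM to 2000 nM.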

Compound 3, half-maximal inhibitory concentration: 11 nM
Estimate against measurement, compound 3: 27-fold (1.44 log units) above; the whole stated range lies above it.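

In this assay, the group on this carbonyl carbon turns out to matter greatly: (3,5-dichlorophenyl)amino in place of 4-(trifluoromethoxy)phenyl gives a 250-fold lower number from compound 2 to compound 3 (2.40 log units; beyond the scatter). This single change adds a nitrogen bearing one hydrogen-bond donor and also replaces the trifluoromethoxy group with two chlorine atoms, so the step belongs to the change as a whole and not to either part of it. The exact size of the step should be read with some care, as repeated entries in this assay can lie far apart: the several entries of compound 1 in this assay, 1450 nM; 39 nM (2 entries).

The compounds shown leave open whether the step follows the added nitrogen or the chlorine atoms. A 3,5-dichlorophenyl group directly on the carbonyl carbon, or a (4-(trifluoromethoxy)phenyl)amino group on the core of compound 2, would separate the two.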